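From 2,6-dichlorobenzyl to 2,4-dichlorobenzyl: working notes

The source may report more compounds than this note shows. Statements on the series, on what has been measured and on what is new or still open speak of the compounds shown alone.

Measured so far in a functional assay on HL-60 cells (Homo sapiens) for antiproliferative activity, with a stated time of 24 h; a higher number here means a weaker inhibitor, a lower number a stronger inhibitor:
- compound 1 `NC(=O)c1c(NC(=O)c2ccccc2Cl)sc2c1CCN(Cc1ccccc1)C2` gives 12000 nM
- compound 2 `NC(=O)c1c(NC(=O)c2ccccc2Cl)sc2c1CCN(Cc1ccc([N+](=O)[O-])cc1)C2` gives 11400 nM
- compound 3 `NC(=O)c1c(NC(=O)c2ccccc2Cl)sc2c1CCN(Cc1c(Cl)cccc1Cl)C2` gives 4850 nM

Compound 3 stands lowest of the three, and its steps to both others lie beyond the scatter. Compound 4 `NC(=O)c1c(NC(=O)c2ccccc2Cl)sc2c1CCN(Cc1ccc(Cl)cc1Cl)C2` keeps the shared core, with 2,4-dichlorophenyl in place of 2,6-dichlorophenyl on a saturated chain carbon bound to an amine nitrogen in a ring. The change reads 2,4-dichlorophenyl in place of 2,6-dichlorophenyl on a saturated chain carbon bound to an amine nitrogen in a ring and the atoms stay the same, only joined differently.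

Among the measured compounds shown here, three measured steps bear on it. The step of a 1.1-fold lower number from compound 1 to compound 2 (0.02 log units; within the scatter) lies within the scatter, while a 2.5-fold lower number from compound 1 to compound 3 (0.39 log units; beyond the scatter) and a 2.4-fold lower number from compound 2 to compound 3 (0.37 log units; beyond the scatter) are both modest. For the measured compounds named here, compound 3 is the only measured compound with a dichlorobenzyl group, so no two such isomers have been compared. A step no larger than those modest ones is expected, most likely none beyond the scatter, leaning toward a higher number. The estimated step is a 1.3-fold higher number from compound 3 to compound 4 (0.13 log units; within the scatter) on this reasoning. For compound 4 the expected value is 6500 nM with an estimated range from 3000 nM to 13000 nM as the working figure.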

Compound 4, half-maximal inhibitory concentration: 8010 nM
Estimate against measurement, compound 4: 1.2-fold (0.09 log units) below; the range from low to high includes it.
By their numbers in this assay, from the lowest: compounds 3, 4, 2 and 1 (each within the scatter of the next, the first and the last beyond it).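

In this assay, 2,4-dichlorophenyl in place of 2,6-dichlorophenyl on a saturated chain carbon bound to an amine nitrogen in a ring gives a step within the scatter (a 1.7-fold higher number from compound 3 to compound 4 (0.22 log units; within the scatter)), so the two isomers cannot be told apart at this position. Compound 4 also stays within the scatter of the unsubstituted and nitro benzyl compounds (a 1.5-fold lower number from compound 1 to compound 4 (0.18 log units; within the scatter) and a 1.4-fold lower number from compound 2 to compound 4 (0.15 log units; within the scatter)). Among the compounds shown here, compound 3 therefore remains the only compound here with steps beyond the scatter from compound 1 and compound 2, and carrying two chlorines on the benzyl ring does not by itself reproduce that separation.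

Going by these compounds, whether a methoxy group on the benzyl ring, or a longer chain between the ring and the amine nitrogen, would move the number beyond the scatter stays open. No measurement bears on what lies behind these numbers.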